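Cytotoxicity notes: furan-2-yl for 2-aminophenyl on the core

The source may hold more compounds than are shown below. What is called first, only, known or untested is meant among the compounds shown, and "the series" means these compounds.

Compound 1 `Cc1ncc([N+](=O)[O-])n1CCSc1nnc(-c2ccccc2N)o1` is the reference point. In a functional assay on HepG2 cells (Homo sapiens) for cytotoxicity, read by MTT assay, with a stated time of 48 h (a lower number here means a stronger inhibitor, a higher number a weaker inhibitor), compound 1 gives 4500 nM, the highest of the three numbers at hand. Compound 3 `Cc1ncc([N+](=O)[O-])n1CCSc1nnc(-c2ccc([N+](=O)[O-])cc2)o1` gives 4100 nM, which sits within the scatter of compound 1, so no order between these two is claimed. For the measured compounds named here, compound 2 `Cc1ncc([N+](=O)[O-])n1CCSc1nnc(-c2ccccc2[N+](=O)[O-])o1` gives 700 nM; the step of a 6.4-fold lower number from compound 1 to compound 2 (0.81 log units; beyond the scatter) is the only measured step in the set, and it concerns nitro in place of amino on an aromatic carbon.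

The unmeasured compound 4 `Cc1ncc([N+](=O)[O-])n1CCSc1nnc(-c2ccco2)o1` differs from compound 1 as follows: furan-2-yl in place of 2-aminophenyl on an aromatic carbon. Going by the values given here, no measured step covers this exchange. The step from compound 1 to compound 2 shows only that changing the substituent on the aminophenyl ring gave a lower number; replacing that ring by furan-2-yl is a different exchange, and its direction is not fixed by the data. With nothing closer to lean on, the expected step in this assay is a 1.5-fold lower number from compound 1 to compound 4 (0.18 log units; within the scatter), a small move toward a lower number that may well stay within the scatter. Compound 4 is therefore estimated at 3000 nM, in the range 1000 nM to 9000 nM.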

Compound 4, half-maximal inhibitory concentration: 22600 nM
The estimate for compound 4 lay 7.5-fold (0.88 log units) below the measured number; measured number outside the range, above it.
By their numbers in this assay, from the lowest: compound 2; then compounds 3 and 1 (each within the scatter of the next); then compound 4.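

In this assay replacing the whole 2-aminophenyl group on the shared core by furan-2-yl gives a 5.0-fold higher number from compound 1 to compound 4 (0.70 log units; beyond the scatter) and so moves the number upward. For the compounds shown here, the earlier step, a 6.4-fold lower number from compound 1 to compound 2 (0.81 log units; beyond the scatter), kept the six-membered aromatic ring and went toward a lower number, so this is the first measured exchange at this position to go the other way, and the number here responds to a change of the ring itself. No measurement at hand gives a reason for this rise.

The compounds shown leave open whether the higher number goes with losing the amino group or with the change to the five-membered ring. An unsubstituted phenyl and a thiophen-2-yl on the same carbon would bear on that question.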